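Capping the pyrrolidine amine: from compound 3 to compound 4

The source may hold more compounds than are shown below. What is called first, only, known or untested is meant among the compounds shown, and "the series" means these compounds.

Measured so far in a functional assay on HEK293 cells for activation of melanin-concentrating hormone receptor 1 (Rattus norvegicus), read by inositol phosphate accumulation; a higher number here means that more compound is needed for the effect, a lower number that less compound is needed:
- compound 1 `O=C(CCc1ccc(C(F)(F)F)cc1)Nc1ccc2nc(N3CCC(NS(=O)(=O)O)C3)ccc2c1`: 50 nM
- compound 2 `O=C(CCc1ccc(C(F)(F)F)cc1)Nc1ccc2nc(N3CC4CC3CO4)ccc2c1`: 70 nM
- compound 3 `NC1CCN(c2ccc3cc(NC(=O)CCc4ccc(C(F)(F)F)cc4)ccc3n2)C1`: 200 nM

Compound 3 stands with the highest number of the three in this assay; the nearest is compound 2, reached by a 2.9-fold higher number from compound 2 to compound 3 (0.46 log units; beyond the scatter), and the furthest is compound 1, reached by a 4.0-fold higher number from compound 1 to compound 3 (0.60 log units; beyond the scatter).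

Compound 4 `CNC(=O)NC1CCN(c2ccc3cc(NC(=O)CCc4ccc(C(F)(F)F)cc4)ccc3n2)C1` differs from compound 3 by methylcarbamoyl in place of hydrogen on an amine nitrogen, that is, amino to (methylcarbamoyl)amino on the same saturated ring carbon.

Among the measured compounds shown here, only one measured step touches this amine nitrogen directly: a 4.0-fold higher number from compound 1 to compound 3 (0.60 log units; beyond the scatter), where removing the sulfo group raised the number beyond the scatter. Compound 2, with no amine at all, sits between the two. For the measured compounds named here, a capped nitrogen therefore appears favoured over a free one in this small set, though no step shows a carbamoyl group itself, so the size is uncertain. For compound 4 a step of a 2.5-fold lower number from compound 3 to compound 4 (0.40 log units; beyond the scatter) is expected, towards a lower number. Compound 4 is estimated at 80 nM, with a range of 30 nM to 250 nM.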

Compound 4, half-maximal effective concentration: 30 nM
Compound 4: middle estimate off by 2.7-fold (0.43 log units), on the high side; the measured number falls inside the stated range.
By their numbers in this assay, from the lowest: compounds 4, 1 and 2 (each within the scatter of the next, the first and the last beyond it); then compound 3.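

In this assay, methylcarbamoyl on the amine nitrogen gives a clear drop in the number (a 6.7-fold lower number from compound 3 to compound 4 (0.82 log units; beyond the scatter)), which makes it the second cap at this position, after sulfo, to stand apart from the free amine beyond the scatter. Methylcarbamoyl and sulfo cannot be told apart here (a 1.7-fold lower number from compound 1 to compound 4 (0.22 log units; within the scatter)), so two caps made of quite different atoms give equivalent results on this nitrogen. Among the compounds shown here, compound 4 is also the first compound to fall beyond the scatter on the low side of the bridged bicyclic amine of compound 2 (a 2.3-fold lower number from compound 2 to compound 4 (0.37 log units; beyond the scatter)).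

As far as these compounds go, whether an acetyl, methanesulfonyl or dimethylcarbamoyl group on this nitrogen would match methylcarbamoyl remains open. Nothing available accounts for the effect of capping this nitrogen.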